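Benzyl for pyrimidinyl on the piperazine ring of a sulfamate amide

The compounds below may be only part of what the source reports. "The series", "measured", "known", "first", "only" and "open" are said of these compounds alone.

Measured compounds:
compound 1, `NS(=O)(=O)Oc1ccc2c(c1)CN(C(=O)c1ccc(N3CCN(c4ncccn4)CC3)cc1)CC2`, 1.93
compound 2, `NS(=O)(=O)Oc1ccc2c(c1)CN(C(=O)c1ccc(N(CCCO)Cc3ccccc3)cc1)CC2`, 1.93
compound 3, `CN(CCN1CCCCC1)c1ccc(C(=O)N2CCc3ccc(OS(N)(=O)=O)cc3C2)cc1`, 1.93

Of the compounds shown here, three sharing a common core have been measured in a physicochemical assay for lipophilicity; a higher number here means a more lipophilic compound, a lower number a more polar compound. Compound 1 gives 1.93, compound 2 gives 1.93 and compound 3 gives 1.93. At the digits shown compound 1 stands level with compounds 2 and 3; the nearest of them is compound 2, the furthest compound 3, and neither gap reaches beyond the scatter. Within the data shown here, no pair among the three differs in only one place, so no single step can be read from them.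

The next compound, compound 4, is `NS(=O)(=O)Oc1ccc2c(c1)CN(C(=O)c1ccc(N3CCN(Cc4ccccc4)CC3)cc1)CC2`. Against compound 1 the change is benzyl in place of pyrimidin-2-yl on an amine nitrogen in a ring. The group that leaves brings two hydrogen-bond acceptors with it; the group that enters brings none, and the count of heavy atoms rises by one. Among the measured compounds shown here, since the measured compounds offer no step of this kind, the expectation rests on those counts alone: a modest rise in this assay, at the edge of the scatter rather than clearly beyond it. The estimated step is a number 0.37 log units higher from compound 1 to compound 4 (beyond the scatter). Compound 4 is thus expected to give 2.3, with a range from 1.6 to 3.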

Compound 4, partition coefficient: 1.93
The estimate for compound 4 lay 0.37 log units above the measured number; the range from low to high includes it.
By their numbers in this assay, from the lowest: compounds 1, 2, 3 and 4 (each within the scatter of the next).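

In this assay, putting benzyl in place of pyrimidin-2-yl on an amine nitrogen in a ring gives no change at the digits printed from compound 1 to compound 4 (within the scatter). Among these compounds, this is the first step in the set that can be read, since the earlier compounds shared a value but differed in more than one place. It shows that at this place on the six-membered ring with 2 nitrogen, an aromatic ring of carbon only can take the place of one with 2 hetero atoms, with the hydrogen-bond acceptors of pyrimidin-2-yl gone and one heavy atom added, without the read-out leaving the scatter. Nothing available offers an explanation of this result.

As far as these compounds go, with a single step at this place, it remains open whether a group of a different kind on the same nitrogen, such as a carboxylic acid, a primary amine or a longer chain ending in a phenyl ring, would shift the number beyond the scatter. From the compounds shown here alone, it is also open whether benzyl in place of pyrimidin-2-yl would give the same outcome on a core other than that of compound 1.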